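Chloro for Fluoro in Two Benzyl Ether Series

This account rests on a few compounds, and the source may have more. Where it says the series, first, only, none or still open, it means among the compounds named here.

Compound 2 `O=C1OCc2cc(OCc3ccc(F)cc3)ccc21` and compound 1 `O=C1OCc2cc(OCc3ccc(Cl)cc3)ccc21` share one core and differ in a single substituent. In an assay on isolated protein for inhibition of Amine oxidase [flavin-containing] A (Homo sapiens), read by fluorescence, with a stated time of 15 min (a higher number here means a weaker inhibitor, a lower number a stronger inhibitor), compound 2 gives 1330 nM. In this assay compound 1 gives 3610 nM. The change between them is chloro in place of fluoro on an aromatic carbon, and it produced a 2.7-fold higher number from compound 2 to compound 1 (0.43 log units; beyond the scatter), a step toward a weaker inhibitor.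

Compound 3 `CC(=O)c1ccc(OCc2cccc(F)c2)cc1F` belongs to a different core; how its core differs from that of compound 2 is not broken down here. In this assay compound 3 reaches only a limit, > 100000 nM, which is the limit at which (the limit of > 100000 nM in this assay, at which 1 of the 3 values shown sits). Compound 4 `CC(=O)c1ccc(OCc2cccc(Cl)c2)cc1F` is the not-yet-measured partner of compound 3, made by chloro in place of fluoro on an aromatic carbon. The surrounding of the place is not the same as in the first pair: in the first pair the chloro enters para to a large group, here it enters meta to a large group, so it is the same kind of change rather than the same change.

For compound 4 the expectation is that it remains beyond the limit in this assay, that is, compound 4 is estimated at about 200000 nM, with an expected step that the limit leaves unreadable from compound 3 to compound 4. This expectation rests on compound 3 already sitting at the limit and on a 2.7-fold higher number from compound 2 to compound 1 (0.43 log units; beyond the scatter) having pointed toward weaker inhibition, although the two places around the change are not identical.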

Compound 4, half-maximal inhibitory concentration: > 100000 nM
Compound 4: a limit, no number (the forecaster's own chance of this, stated with the estimate: 85%); the middle value is on the limit's open side.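

Compound 3 and compound 4 both reach only a limit in this assay, so no size or direction can be read for the change from fluoro to chloro between them: the limit of > 100000 nM in this assay, at which 2 of the 4 values shown sit.

The compounds shown leave open how strongly compound 3 and compound 4 inhibit, and whether chloro in place of fluoro on their core would give a step like the one between compound 2 and compound 1.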